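Trimming One Methyl from the Piperazine Ring of Compound 3

The compounds below may be only part of what the source reports. "The series", "measured", "known", "first", "only" and "open" are said of these compounds alone.

Compound 1 `COc1cc2c(cc1N1C[C@@H](C)N[C@@H](C)C1)N(S(=O)(=O)c1ccc(-c3ccccn3)s1)CC2`: 0.9
Compound 2 `COc1cc2c(cc1N1CCNCC1)N(S(=O)(=O)c1ccc(-c3ccccn3)s1)CC2`: 0.8
Compound 3 `COc1cc2c(cc1N1C[C@@H](C)NC(C)(C)C1)N(S(=O)(=O)c1ccc(-c3ccccn3)s1)CC2`: 0.8

In a functional assay with growth hormone secretagogue receptor type 1 (Homo sapiens) as the target (a lower number here means a smaller maximal response, a higher number a larger maximal response), compound 3 gives 0.8, level with compound 2 and within the usual scatter of compound 1. The steps a number 0.10 lower from compound 1 to compound 3 (within the scatter) and no change at the digits printed from compound 2 to compound 3 (within the scatter) both swapped methyl groups on the saturated ring without any effect beyond the scatter. Compound 4 `COc1cc2c(cc1N1CCNC(C)(C)C1)N(S(=O)(=O)c1ccc(-c3ccccn3)s1)CC2` differs from compound 3 by one such change: hydrogen in place of methyl on a saturated ring carbon. Since the two measured steps that reshaped this ring left the maximal response essentially unchanged, no shift beyond the scatter is expected here, and the expected step is no change at the digits printed from compound 3 to compound 4 (within the scatter). Compound 4 is therefore estimated at 0.8, with a range from 0.7 to 0.9.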

Compound 4, intrinsic activity: the largest response reached, as a fraction of the reference agonist's: 0.9
Compound 4: middle estimate off by 0.10, on the low side; the measured number falls inside the stated range.
By their numbers in this assay, from the lowest: compounds 2, 3, 1 and 4 (each within the scatter of the next).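

In this assay, hydrogen in place of methyl on this saturated ring carbon gives a number 0.10 higher from compound 3 to compound 4 (within the scatter), so the maximal response does not distinguish the two at this position. The same holds for 3,3-dimethylpiperazin-1-yl in place of piperazin-1-yl, which gives a number 0.10 higher from compound 2 to compound 4 (within the scatter), and in place of 3,5-dimethylpiperazin-1-yl, which gives no change at the digits printed from compound 1 to compound 4 (within the scatter). No evidence is available to explain these steps. Still open, as far as these compounds go, is whether an ethyl or hydroxymethyl group on this ring carbon would keep the maximal response within the scatter.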